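Taking the 4-cyanobenzyl group off compound 2

A few compounds are considered here, and "the series" means these few. Any claim that something is new, unique, unknown or untested is made for them only; others in the source may bear on it.

Values in an ADME assay on CHO cells (Cricetulus griseus) for inhibition, read by MTT assay; a higher number here means a weaker inhibitor, a lower number a stronger inhibitor:
Compound 1 `CCN(CC)Cc1cccc(Nc2nc3ccccc3n2Cc2ccc(C#N)cc2)c1O`: > 50000 nM (a limit)
Compound 2 `CCN(CC)Cc1ccc(C)c(Nc2nc3ccccc3n2Cc2ccc(C#N)cc2)c1O`: > 50000 nM (a limit)
Compound 3 `CCN(CC)Cc1cc(Nc2nc3ccccc3n2Cc2ccc(F)cc2)ccc1O`: 12000 nM

Compound 2 gives > 50000 nM, which is a limit and not an exact number. The data show (the limit of > 50000 nM in this assay, at which 2 of the 3 values shown sit). Compound 4 `CCN(CC)Cc1ccc(C)c(Nc2nc3ccccc3[nH]2)c1O` arises from compound 2 by hydrogen in place of 4-cyanobenzyl on an aromatic nitrogen. Going by the values given here, no measured step covers this change. The only one, a step that the two limits leave unreadable from compound 1 to compound 2, concerns a methyl group instead. Compound 3 gives 12000 nM, but it differs from compound 2 in more than one place. So no sized step can be carried over to this assay, and no clear direction is expected. The expected change is a step that the limit leaves unreadable from compound 2 to compound 4. Compound 4 is estimated at 60000 nM, within an expected range of 15000 nM to 200000 nM.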

Compound 4, half-maximal inhibitory concentration: > 50000 nM
Compound 4: a limit, no number; the forecaster's own chance of this, stated with the estimate: 65%; the middle value lies beyond the limit too.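

In this assay compound 4 gives > 50000 nM, a limit and not a number. Compound 2 also stands at a limit, so no step can be read between compound 2 and compound 4. As far as these compounds go, how far hydrogen in place of 4-cyanobenzyl shifts inhibition stays open.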